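A few compounds are considered here, and "the series" means these few. Any claim that something is new, unique, unknown or untested is made for them only; others in the source may bear on it.

For the measured compounds named here, in a functional assay on B16-F10 cells (Mus musculus) for inhibition, read by MTT assay, with a stated time of 72 h (on this read-out higher numbers stand for weaker inhibition of growth and lower numbers for stronger inhibition of growth), compound 1 (`CC(C)=CC(=O)NC(=N)N`) gives 92800 nM, the higher of the two numbers so far, while compound 2 (`C=C1CCCC(C)(C)[C@@H]1CC/C(C)=C/C(=O)NC(=N)NC(=O)C=C(C)C`) gives 9600 nM. Compound 3 (`CC(C)=CCC/C(C)=C/C(=O)NC(=N)N`) departs from compound 1 by 3-methylbut-2-en-1-yl in place of hydrogen on a saturated chain carbon bound to a double-bonded chain carbon. Going by the values given here, no measured pair isolates this change. The only pointer is the larger compound 2 at 9600 nM, so the evidence is thin. The expected step is a 2.7-fold lower number from compound 1 to compound 3 (0.42 log units; beyond the scatter), towards stronger inhibition of growth and beyond the scatter. For compound 3 the estimated value is 35000 nM, with an expected range of 12000 nM to 90000 nM.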

Compound 3, concentration for 50% growth inhibition: 17100 nM
Estimate against measurement, compound 3: 2.0-fold (0.31 log units) above, within the range that was stated.
By their numbers in this assay, from the lowest: compounds 2 and 3 (each within the scatter of the next); then compound 1.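

In this assay, 3-methylbut-2-en-1-yl in place of hydrogen on a saturated chain carbon bound to a double-bonded chain carbon gives a 5.4-fold lower number from compound 1 to compound 3 (0.73 log units; beyond the scatter) and thus moves towards stronger inhibition of growth. For the compounds shown here, this isolates the change for the first time and shows that the position accepts this group without loss of growth inhibition. No measurement in hand explains the step.

A methyl or a longer chain at this position would show how the number follows chain length. A saturated 3-methylbutyl group or a terminal amine would test whether the double bond or the hydrocarbon end matters.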